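Exchanging a Tolyl Ring for a Pyrimidinyl Ring

The compounds below may be only part of what the source reports. "The series", "measured", "known", "first", "only" and "open" are said of these compounds alone.

Going by the values given here, compound 2 `Cc1ccc(-c2cnc(Nc3ccc(C#N)cc3)nc2Oc2c(C)cc(C#N)cc2C)cc1` is the only member of this small set with a measured number: in an ADME assay on MT4 cells (Homo sapiens) for cytotoxicity, read by MTT assay, with a stated time of 5 days (a lower number here means that less compound is tolerated, a higher number that more compound is tolerated), compound 2 gives 26100 nM. Compound 1 `COc1ccc(-c2cnc(Nc3ccc(C#N)cc3)nc2Oc2c(C)cc(C#N)cc2C)cc1` reaches only a limit of this assay, > 279000 nM. Compound 3 `Cc1cc(C#N)cc(C)c1Oc1nc(Nc2ccc(C#N)cc2)ncc1-c1ccc(-c2ccccc2)cc1` likewise sits at a limit, > 253000 nM. Compound 4 `Cc1cc(C#N)cc(C)c1Oc1nc(Nc2ccc(C#N)cc2)ncc1-c1cncnc1` remains to be measured; it differs from compound 2 in one place: pyrimidin-5-yl in place of 4-methylphenyl on an aromatic carbon.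

Two measured steps alter the same ring. Methyl in place of methoxy gave an at least 10-fold lower number from compound 1 to compound 2 (1.02 log units; beyond the scatter), and phenyl in place of methyl gave an at least 9.6-fold higher number from compound 2 to compound 3 (0.98 log units; beyond the scatter). Both neighbours of compound 2 thus lie at the upper end of what this assay reports, namely the limit of > 279000 nM in this assay, at which 1 of the 3 values shown sits, and (the limit of > 253000 nM in this assay, at which 1 of the 3 values shown sits). Among the compounds with values here, no measured step replaces the carbon ring by one carrying two nitrogen atoms, so the size of the coming step is uncertain, but every change so far at this position has moved the number upward from compound 2. The writer therefore expects a modest to large rise, a 4.6-fold higher number from compound 2 to compound 4 (0.66 log units; beyond the scatter), possibly ending again at a limit. For compound 4 the estimate is 120000 nM, within a range of 30000 nM to 300000 nM.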

Compound 4, half-maximal cytotoxic concentration: > 298000 nM
Compound 4 gave a limit, no number (the forecaster's own chance of this, stated with the estimate: 45%); middle value at least 2.4-fold (0.39 log units) from the limit.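

Pyrimidin-5-yl in place of 4-methylphenyl gave an at least 11-fold higher number from compound 2 to compound 4 (1.05 log units; beyond the scatter), so a ring carrying nitrogen at this position, para to the (4-cyanophenyl)amino group, goes the same way as the carbon rings of compound 1 and compound 3. Going by these compounds alone, this change alters the ring itself, not only the group on it, and compound 2 remains the only one of the four compounds with a number. Compound 4 reaches a limit in this assay, not a number: the limit of > 298000 nM in this assay, at which 1 of the 4 values shown sits.

The steps among compound 1, compound 3 and compound 4 cannot be read, as each joins two limits. From the compounds shown here alone, it stays open whether a pyridin-3-yl ring, with a single ring nitrogen, or a 4-ethylphenyl group would give a number like that of compound 2 or would also reach a limit.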